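The compounds below may be only part of what the source reports. "The series", "measured", "known", "first", "only" and "open" are said of these compounds alone.

Compound 3 `Cc1noc(-c2ccccc2NCC2=NCCN2)n1` belongs to a set of three measured compounds built on the shared core of compound 1 `c1coc(-c2ccccc2NCC2=NCCN2)c1`, each carrying a different five-membered heteroaromatic group on an aromatic carbon. In a functional assay for activation of Alpha-1D adrenergic receptor (Homo sapiens) (on this read-out higher numbers stand for an effect only at larger amounts of compound and lower numbers for an effect already at smaller amounts), compound 1 gives 16.2 nM. Compound 2 `Cc1ncc(-c2ccccc2NCC2=NCCN2)o1` is recorded in this assay only as a limit of the assay, < 5020 nM. Compound 3 likewise stands in this assay at a limit of the assay, < 5020 nM. Because of the limit of < 5020 nM in this assay, at which 2 of the 3 values shown sit, the steps a step that the limit leaves unreadable from compound 1 to compound 2, a step that the limit leaves unreadable from compound 1 to compound 3 and a step that the two limits leave unreadable from compound 2 to compound 3 cannot be read in size, so compound 3 is placed only as a compound with an effect somewhere below that limit. Compound 4 `Cc1nc(-c2ccccc2NCC2=NCCN2)no1` differs from compound 3 by 5-methyl-1,2,4-oxadiazol-3-yl in place of 3-methyl-1,2,4-oxadiazol-5-yl on an aromatic carbon; the two have the same atoms, joined differently. Among the compounds with values here, no measured step bears directly on this exchange, and the three steps that exist are all unreadable. Compound 4 is therefore expected in this assay at 800 nM, with a range from 60 nM to 5000 nM. The step that the limit leaves unreadable from compound 3 to compound 4 that this estimate means is expected to be no more than a guess, with no direction claimed.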

Compound 4, half-maximal effective concentration: < 5020 nM
Compound 4 ended at the assay's limit; the forecaster's own chance of this, stated with the estimate: 40%; the middle value is on the limit's open side.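

The steps from compound 1, compound 2 and compound 3 to compound 4 cannot be read in size, because compound 4 also stands at a limit of the assay: the limit of < 5020 nM in this assay, at which 3 of the 4 values shown sit.

As far as these compounds go, whether 5-methyl-1,2,4-oxadiazol-3-yl and 3-methyl-1,2,4-oxadiazol-5-yl differ at all in this assay stays open, as does how far compound 2, compound 3 and compound 4 lie from compound 1.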